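The compounds below may be only part of what the source reports. "The series", "measured", "known", "first", "only" and "open" are said of these compounds alone.

Compound 1 `COc1nc(C(C)(C)C)ccc1[C@@H](c1ccccc1)[C@@](O)(CCN(C)C)c1cccc2ccccc12` gives > 64 ug/mL in a toxicity assay on HeLa cells (Homo sapiens) for cytotoxicity; on this read-out higher numbers stand for lower toxicity in this test and lower numbers for higher toxicity in this test.
Compound 2 `COc1ccc(-c2ccc([C@@H](c3ccccc3)[C@@](O)(CCN(C)C)c3cccc4ccccc34)c(OC)n2)cc1` gives > 64 ug/mL in this assay.
Compound 3 `COc1nc(-c2ccc(C(F)(F)F)cc2)ccc1[C@@H](c1ccccc1)[C@@](O)(CCN(C)C)c1cccc2ccccc12` gives > 64 ug/mL in this assay.

Each of these three values is a limit of the assay, not a number; no compound shown here reached a readable concentration in this assay. Compound 3 therefore stands at the limit of > 64 ug/mL in this assay, at which 3 of the 3 values shown sit, together with the other two, and nothing distinguishes it from them on the figures shown.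

The next compound, compound 4 `COc1nc(-c2cnsc2)ccc1[C@@H](c1ccccc1)[C@@](O)(CCN(C)C)c1cccc2ccccc12`, is reached from compound 3 by one change: 1,2-thiazol-4-yl in place of 4-(trifluoromethyl)phenyl on an aromatic carbon. The steps measured so far all bear on this position of the shared core: a step that the two limits leave unreadable from compound 1 to compound 2, a step that the two limits leave unreadable from compound 1 to compound 3 and a step that the two limits leave unreadable from compound 2 to compound 3. All three are unreadable, since both ends sit at the same limit, so no size or direction of step can be drawn from them.

With every shown value at the limit of > 64 ug/mL in this assay, at which 3 of the 3 values shown sit, compound 4 is expected to remain there as well, with an estimated step that the limit leaves unreadable from compound 3 to compound 4 not beyond the scatter. The estimate for compound 4 in this assay is 80 ug/mL, within a range from 40 ug/mL to 200 ug/mL.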

Compound 4, half-maximal cytotoxic concentration: 28.8 ug/mL
Compound 4: the middle estimate sits 2.8-fold (0.44 log units) above what was measured; the measured number lies below the stated range.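

This position of the shared core can change the read-out in this assay, where a lower number stands for higher toxicity in this test: the 1,2-thiazol-4-yl group gives an at least 2.2-fold lower number from compound 3 to compound 4 (0.34 log units; beyond the scatter), an at least 2.2-fold lower number from compound 2 to compound 4 (0.34 log units; beyond the scatter) and an at least 2.2-fold lower number from compound 1 to compound 4 (0.34 log units; beyond the scatter). Among the compounds shown here, the steps among compound 1, compound 2 and compound 3 cannot be read, so these three steps are the first evidence that a change here matters. Each is only a minimum, as the value at the start of each step is a limit of the assay, not a number: the limit of > 64 ug/mL in this assay, at which 3 of the 4 values shown sit.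

With a single readable compound, the figures cannot separate the sulfur and nitrogen of the new ring from its count of 5 heavy atoms. From the compounds shown here alone, how a plain phenyl, a thienyl ring, a pyridyl ring or an amine at this place would compare also stays open.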